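The source may report more compounds than this note shows. Statements on the series, on what has been measured and on what is new or still open speak of the compounds shown alone.

Measured so far:
- compound 1, `N#Cc1cnc(NCc2cnccc2C(F)(F)F)cc1NC[C@H]1C[C@@H](O)C1`, in an assay on isolated protein for inhibition of protein kinase C theta type (Homo sapiens), read by TR-FRET, with a stated time of 2 h (on this read-out higher numbers stand for weaker inhibition and lower numbers for stronger inhibition), compound 1 gives 300 nM
- compound 2, `CC1(C)C[C@@H](Nc2cc(NCc3cnccc3C(F)(F)F)ncc2C#N)CC[C@H]1O`, in this assay compound 2 gives 120 nM

Among the compounds with values here, compound 2 stands at the lower of the two numbers; its only neighbour is compound 1, and the one measured step is a 2.5-fold lower number from compound 1 to compound 2 (0.40 log units; beyond the scatter), a modest gain that lies beyond the scatter. Compound 3, `CC1(C)[C@@H](Nc2cc(NCc3cnccc3C(F)(F)F)ncc2C#N)C[C@H]1C(N)=O`, has not yet been measured in this assay. It differs from compound 2 in one place: 3-carbamoyl-2,2-dimethylcyclobutyl in place of 4-hydroxy-3,3-dimethylcyclohexyl on a nitrogen on an aromatic ring. The change thus returns to a four-membered ring, as in compound 1, but attached directly to the nitrogen and carrying a carbamoyl group instead of a hydroxyl, with the two methyl groups retained. The step of a 2.5-fold lower number from compound 1 to compound 2 (0.40 log units; beyond the scatter) bears on it only loosely, since compound 1 had the four-membered ring linked through a methylene and bore a hydroxyl rather than a carbamoyl. A move back toward a smaller ring is expected to give back part of that gain, and compound 3 is therefore expected to show a step of a 2.1-fold higher number from compound 2 to compound 3 (0.32 log units; beyond the scatter), toward a weaker result. The estimate for compound 3 in this assay is 250 nM, with a range from 80 nM to 800 nM.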

Compound 3, half-maximal inhibitory concentration: 140 nM
For compound 3 the middle estimate is 1.8-fold (0.25 log units) above the measured one; measured number inside the range.
By their numbers in this assay, from the lowest: compounds 2 and 3 (each within the scatter of the next); then compound 1.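

In this assay, the 3-carbamoyl-2,2-dimethylcyclobutyl group on the aromatic-ring nitrogen cannot be told apart from the 4-hydroxy-3,3-dimethylcyclohexyl group, with a 1.2-fold higher number from compound 2 to compound 3 (0.07 log units; within the scatter). This position therefore tolerates a four-membered carbon ring as well as a six-membered one, and a carbamoyl group as well as a hydroxyl, at least in these two combinations. Against the (3-hydroxycyclobutyl)methyl group, the new group gives a 2.1-fold lower number from compound 1 to compound 3 (0.33 log units; beyond the scatter), which shows that a four-membered ring does not by itself bring the higher number seen for compound 1, and nothing available here explains these results.

Ring size and the end group differ together between compound 2 and compound 3, so the part played by each remains unresolved, as does the part played by the two methyl groups. Also open, going by these compounds, is how a carboxylic acid or an amine in place of the carbamoyl group on the 2,2-dimethylcyclobutyl ring would read in this assay.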